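Adding a Fluorine to the Cinnamyl Ring of Compound 3

The source may hold more compounds than are shown below. What is called first, only, known or untested is meant among the compounds shown, and "the series" means these compounds.

Of the compounds shown here, three have been measured in an assay on cell membranes from brain for inhibition of sodium-dependent dopamine transporter (Rattus norvegicus); a higher number here means a weaker inhibitor, a lower number a stronger inhibitor. Compound 1 `Fc1ccc(/C=C/CN2CCC(CCOC(c3ccc(F)cc3)c3ccc(F)cc3)CC2)cc1` gives 15.1 nM; compound 2 `Fc1ccc(C(OCCC2CCN(C/C=C/c3ccccc3)CC2)c2ccc(F)cc2)cc1` gives 41.4 nM; compound 3 `C(=C/c1ccccc1)\CN1CCC(CCOC(c2ccccc2)c2ccccc2)CC1` gives 10.1 nM. Compound 3 thus has the lowest number of the three, but its gap to compound 1 lies within the scatter, while its gap to compound 2 lies beyond it.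

Compound 4 `Fc1ccc(/C=C/CN2CCC(CCOC(c3ccccc3)c3ccccc3)CC2)cc1` differs from compound 3 by fluoro in place of hydrogen on an aromatic carbon. For the measured compounds named here, the one measured step that bears on this is the reverse change at the same place: a 2.7-fold higher number from compound 1 to compound 2 (0.44 log units; beyond the scatter). Going the other way, from compound 3 to compound 4, a fluorine is added rather than removed, so a lower number of comparable size is expected in this assay, which would be a 2.0-fold lower number from compound 3 to compound 4 (0.31 log units; beyond the scatter). Compound 4 is therefore estimated at 5 nM, with a likely range from 2 nM to 15 nM.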

Compound 4, half-maximal inhibitory concentration: 10.8 nM
For compound 4 the middle estimate is 2.2-fold (0.33 log units) below the measured one, and the stated range covers the measured number.
By their numbers in this assay, from the lowest: compounds 3, 4 and 1 (each within the scatter of the next); then compound 2.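

In this assay, fluoro in place of hydrogen on this aromatic carbon gives a 1.1-fold higher number from compound 3 to compound 4 (0.03 log units; within the scatter), so on the core of compound 3 the change has no measurable effect. The earlier pair alone suggested that a fluorine here matters, but that reading now holds only for the core of compound 1, where the other two aromatic rings also carry fluoro. The effect of this one change thus depends on the core that carries it: the same change on two cores in this assay, a 2.7-fold higher number (0.44 log units; beyond the scatter) from compound 1 to compound 2 and a 1.1-fold lower number (0.03 log units; within the scatter) from compound 4 to compound 3, 2.9-fold (0.47 log units) apart, beyond the scatter of two such steps

On these data alone, it remains open whether both fluoro groups on those other rings are needed for this dependence, or whether one would be enough. Also open, as far as these compounds go, is how this aromatic carbon would respond to a chloro, a methoxy or an amine in place of fluoro, on either core.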